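Swapping the aryl on the carbonyl: expected tolerance

This account rests on a few compounds, and the source may have more. Where it says the series, first, only, none or still open, it means among the compounds named here.

Compound 1 `Cc1ccccc1C(=O)N(C(=S)OCCN1C(=O)c2ccccc2C1=O)c1ccc(Cl)cc1` gives 21000 nM in an ADME assay on MT4 cells (Homo sapiens) for cytotoxicity, read by MTT assay; a higher number here means that more compound is tolerated, a lower number that less compound is tolerated.
Compound 2 `Cc1ccc(N(C(=O)c2ccccc2C)C(=S)OCCN2C(=O)c3ccccc3C2=O)cc1` gives only a limit of the assay, > 100000 nM.
Compound 3 `O=C1c2ccccc2C(=O)N1CCOC(=S)N(C(=O)c1cccc(F)c1F)c1ccc(Cl)cc1` gives 58000 nM.

Compound 2 therefore stands at the limit, with no exact number known, and the step of an at least 4.7-fold higher number from compound 1 to compound 2 (0.67 log units; beyond the scatter) is itself only a lower bound. Compound 4 `Cc1ccc(N(C(=O)c2c(Cl)cccc2Cl)C(=S)OCCN2C(=O)c3ccccc3C2=O)cc1` arises from compound 2 by the change (2,6-dichlorophenyl in place of 2-methylphenyl on a carbonyl carbon). Among the measured compounds shown here, the only measured step at this position is a 2.8-fold higher number from compound 1 to compound 3 (0.44 log units; beyond the scatter), a modest rise when the aryl on the carbonyl carbon was exchanged. A comparably small step, a number no higher from compound 2 to compound 4 (the limit leaves the size open), is expected here, most likely leaving compound 4 at the limit again. Compound 4 is estimated at 100000 nM, within a range from 40000 nM to 300000 nM.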

Compound 4, half-maximal cytotoxic concentration: 22000 nM
For compound 4 the middle estimate is 4.5-fold (0.66 log units) above the measured one, and the stated range ends above it.
By their numbers in this assay, from the lowest: compounds 1 and 4 (each within the scatter of the next); then compound 3. At a limit, above all of these: compound 2.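

In this assay, the aryl on the carbonyl carbon can also reduce tolerance: 2,6-dichlorophenyl gives an at least 4.5-fold lower number from compound 2 to compound 4 (0.65 log units; beyond the scatter), whereas 2,3-difluorophenyl gave a 2.8-fold higher number from compound 1 to compound 3 (0.44 log units; beyond the scatter). These opposite steps start from different compounds, one carrying methyl and the other chloro on the second aromatic ring, so they show no single trend for this position. The fall from compound 2 has no exact size: the limit of > 100000 nM in this assay, at which 1 of the 4 values shown sits.

From the compounds shown here alone, whether both chlorines are needed for this fall remains open. So does how tolerance would respond to an amine or a carboxylic acid on this aryl.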